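Nitroimidazole alkyl series: pyrrolidine in place of bromide

The source may hold more compounds than are shown below. What is called first, only, known or untested is meant among the compounds shown, and "the series" means these compounds.

Of the compounds shown here, three of the shared core have been read in an ADME assay on J774 cells (Mus musculus) for cytotoxicity, read by resazurin assay, with a stated time of 24 h; on this read-out higher numbers stand for weaker inhibition and lower numbers for stronger inhibition. Compound 2 `Cc1ncc([N+](=O)[O-])n1CCCCCCBr` gives 69.9 ug/mL, and compound 1 `Cc1ncc([N+](=O)[O-])n1CCCCBr` gives 61 ug/mL; the step of a 1.1-fold higher number from compound 1 to compound 2 (0.06 log units; within the scatter) is within the scatter, so the two sit together. Compound 3 `Cc1ncc([N+](=O)[O-])n1CCCCCN1CCCCC1` is reported only as a limit, > 100 ug/mL, in this assay. The step of an at least 1.4-fold higher number from compound 2 to compound 3 (0.15 log units; that floor lies within the scatter) therefore has a floor that also lies within the scatter, and the limit of > 100 ug/mL in this assay, at which 1 of the 3 values shown sits, leaves its true size open.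

Compound 4 `Cc1ncc([N+](=O)[O-])n1CCCCN1CCCC1` is the next member to be read. It differs from compound 2 by pyrrolidin-1-yl in place of 2-bromoethyl on a saturated chain carbon, four bonds along the chain from an aromatic nitrogen. For the measured compounds named here, the nearest measured step is the one from compound 2 to compound 3, where a cyclic amine replaces a bromide at the chain end and the number rises at least to the limit; the step from compound 1 to compound 2 shows that chain length alone changes little. On this basis compound 4 is expected to move in the same direction as compound 3, with an estimated step of a 1.6-fold higher number from compound 2 to compound 4 (0.20 log units; within the scatter) and a fair chance of reaching the limit again. The estimate for compound 4 is 110 ug/mL, with a range from 55 ug/mL to 220 ug/mL.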

Compound 4, half-maximal inhibitory concentration: > 100 ug/mL
Compound 4 was reported as a limit; the forecaster's own chance of this, stated with the estimate: 60%; the middle value is on the limit's open side.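

Compound 4 is reported only as a limit, > 100 ug/mL in this assay, so a second cyclic amine at the chain end, here pyrrolidin-1-yl rather than the piperidin-1-yl of compound 3, also gives no measured number, while both bromides, compound 1 and compound 2, do. The floors of the new steps, an at least 1.4-fold higher number from compound 2 to compound 4 (0.15 log units; that floor lies within the scatter) and an at least 1.6-fold higher number from compound 1 to compound 4 (0.21 log units; that floor lies within the scatter), establish no change beyond the scatter, so the replacement of bromide by amine is a consistent direction across these compounds and not a sized effect. Neither amine-bearing compound can be ranked against the other, and their true distance from the bromides stays unread: the limit of > 100 ug/mL in this assay, at which 2 of the 4 values shown sit.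

Still open, as far as these compounds go, is how far beyond the limit compound 3 and compound 4 lie. Also open, from the compounds shown here alone, is whether an open-chain amine such as diethylamino, or a carboxylic acid, at the chain end would give a readable number.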